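A few compounds are considered here, and "the series" means these few. Any claim that something is new, unique, unknown or untested is made for them only; others in the source may bear on it.

Working notes on the series in a functional assay on B16 cells (Mus musculus) for antiproliferative activity, with a stated time of 72 h; a lower number here means a stronger inhibitor, a higher number a weaker inhibitor. Compound 1 (`OC[C@H]1O[C@@H](n2cnc3c(NCc4ccc(Br)cc4)ncnc32)[C@H](O)[C@@H]1O`) gives > 166000 nM, which is a limit of the assay and not a number. Compound 2 (`COc1cccc(CNc2ncnc3c2ncn3[C@@H]2O[C@H](CO)[C@@H](O)[C@H]2O)c1`) gives > 166000 nM, which is also a limit. Compound 3 (`COc1cc(CNc2ncnc3c2ncn3[C@@H]2O[C@H](CO)[C@@H](O)[C@H]2O)cc(OC)c1`) has the entry "not determined" (no result reported), so it holds no place of its own on the scale and offers no number to start from.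

Compound 4 (`OC[C@H]1O[C@@H](n2cnc3c(NCc4ccc(F)cc4Cl)ncnc32)[C@H](O)[C@@H]1O`) differs from it by 2-chloro-4-fluorophenyl in place of 3,5-dimethoxyphenyl on a saturated chain carbon bound to a nitrogen on an aromatic ring. In words, this is 2-chloro-4-fluorophenyl in place of 3,5-dimethoxyphenyl on a saturated chain carbon bound to a nitrogen on an aromatic ring.

Within the data shown here, one measured step bears on this change, an exchange at the same place with 3-methoxyphenyl in place of 4-bromophenyl: a step that the two limits leave unreadable from compound 1 to compound 2. Its size cannot be read, so it gives no magnitude or direction to carry over. The only anchor is the limit of > 166000 nM in this assay, at which 2 of the 3 values shown sit, and compound 4 is therefore expected to stay in that region, with no step beyond the scatter and no direction expected. The estimate for compound 4 is 150000 nM, with an estimated range from 40000 nM to 300000 nM.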

Compound 4, half-maximal inhibitory concentration: > 166000 nM
Compound 4: no number, only a limit (the forecaster's own chance of this, stated with the estimate: 70%); at least 1.1-fold (0.04 log units) between middle value and limit.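

In this assay compound 4 gives > 166000 nM, which is a limit of the assay and not a number. Among these compounds, no step among compound 1, compound 2 and compound 4 can be read, as all three stand at limits. The compounds shown leave open whether any group on a saturated chain carbon bound to a nitrogen on an aromatic ring gives a readable value.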